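The source may hold more compounds than are shown below. What is called first, only, known or untested is meant among the compounds shown, and "the series" means these compounds.

Measured compounds:
compound 1 `COc1nc2ccc(Br)cc2cc1C(c1ccccc1)n1cc(-c2ccc(Br)cc2)nn1`: 10.4%
compound 2 `CCCCc1cn(C(c2ccccc2)c2cc3cc(Br)ccc3nc2OC)nn1`: 5.46%
compound 3 `COc1nc2ccc(Br)cc2cc1C(c1ccccc1)n1cc(CCO)nn1`: 19.8%

These three share a core and differ only in the group attached to an aromatic carbon of the five-membered ring. In an ADME assay on PANC-1 cells (Homo sapiens) for cytotoxicity, read by sulforhodamine B assay, with a stated time of 48 h, tested at 10 uM (a lower number here means less inhibition, a higher number more inhibition at the concentration tested (going by the name of the read-out)), compound 3 gives the highest of the three numbers; its nearest neighbour is compound 1, with a number 9.4 percentage points higher from compound 1 to compound 3 (within the scatter), and its furthest is compound 2, with a number 14.3 percentage points higher from compound 2 to compound 3 (beyond the scatter). Compound 4 `COc1nc2ccc(Br)cc2cc1C(c1ccccc1)n1cc(-c2ccc(F)cc2)nn1` has not yet been tested. Compared with compound 3, the change is 4-fluorophenyl in place of 2-hydroxyethyl on an aromatic carbon. Within the data shown here, the step that bears on this most directly is the one from compound 1 to compound 3, where a 4-bromophenyl group gave way to 2-hydroxyethyl and the number moved by a number 9.4 percentage points higher from compound 1 to compound 3 (within the scatter); compound 4 carries the reverse of that exchange with a 4-fluorophenyl instead. The step from compound 1 to compound 2, a number 4.9 percentage points lower from compound 1 to compound 2 (within the scatter), also shows that swapping the group on this carbon moved little. Compound 4 is therefore expected to sit close to compound 1, with an estimated step of a number 8.8 percentage points lower from compound 3 to compound 4 (within the scatter). The estimate for compound 4 in this assay is 11%, between 2% and 22%.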

Compound 4, a percentage reported as inhibition, at one concentration (the size of the read-out at that concentration, not a potency): 14.9%
Compound 4: middle estimate off by 3.9 percentage points, on the low side, and the stated range covers the measured number.
By their numbers in this assay, from the lowest: compounds 2, 1, 4 and 3 (each within the scatter of the next, the first and the last beyond it).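

In this assay, a ring-bearing group with no hydrogen-bond donor or acceptor in place of 2-hydroxyethyl gives a number 4.9 percentage points lower from compound 3 to compound 4 (within the scatter) and so does not set the two groups apart. Among these compounds, changing 4-bromophenyl to 4-fluorophenyl gives a number 4.5 percentage points higher from compound 1 to compound 4 (within the scatter) and is the first comparison here that alters one atom of the aryl group and leaves the rest of the molecule unchanged, while 4-fluorophenyl in place of butyl gives a number 9.4 percentage points higher from compound 2 to compound 4 (within the scatter) and leaves butyl against 2-hydroxyethyl as the only exchange at this carbon with a step beyond the scatter. No independent measurement is available to explain these numbers. The compounds shown leave open how an amine or a carboxylic acid on this carbon would read. A longer chain ending in hydroxy also remains an open comparison with 2-hydroxyethyl.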